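A few compounds are considered here, and "the series" means these few. Any claim that something is new, unique, unknown or untested is made for them only; others in the source may bear on it.

The measured compounds and their values in a functional assay on HT-29 cells (Homo sapiens) for cytotoxicity, read by MTT assay, with a stated time of 24 h; on this read-out lower numbers stand for stronger inhibition and higher numbers for weaker inhibition:

Compound 1, `Cc1ncc([N+](=O)[O-])n1CCOc1ccc(F)cc1`: 102 ug/mL
Compound 2, `Cc1cc(OCCn2c([N+](=O)[O-])cnc2C)ccc1F`: 140 ug/mL
Compound 3, `Cc1ncc([N+](=O)[O-])n1CCn1ccnc1`: 115 ug/mL

Compound 2 is compound 1 with methyl in place of hydrogen on an aromatic carbon, and this gives a 1.4-fold higher number from compound 1 to compound 2 (0.14 log units; within the scatter). Compound 3 is built on a different core from compound 1; the difference between the two cores is not broken down here, and the values of compound 3 and compound 1 in this assay lie within the scatter of each other.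

Compound 4, `Cc1nccn1CCn1c([N+](=O)[O-])cnc1C`, has not yet been measured. It is compound 3 with methyl in place of hydrogen on an aromatic carbon. For the measured compounds named here, this is the same kind of change as the one from compound 1 to compound 2, but not the same: there the methyl entered on a six-membered aromatic ring of carbon only, ortho to a fluoro group and meta to a large group, whereas here it enters on a five-membered aromatic ring with 2 nitrogen, between two ring nitrogen atoms, next to the ring atom that bears a large group.

For compound 4 in this assay the expected step is a 1.2-fold higher number from compound 3 to compound 4 (0.09 log units; within the scatter), resting on the step of a 1.4-fold higher number from compound 1 to compound 2 (0.14 log units; within the scatter), which stayed within the scatter. Compound 4 is therefore estimated at 140 ug/mL, with a range from 70 ug/mL to 280 ug/mL.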

Compound 4, half-maximal inhibitory concentration: 142 ug/mL
Beside the measured number, compound 4's estimate is 1.0-fold (0.01 log units) below it; the measured number falls inside the stated range.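

In this assay, methyl in place of hydrogen on an aromatic carbon gives a 1.2-fold higher number from compound 3 to compound 4 (0.09 log units; within the scatter), and set beside the earlier case, the change reads alike on both cores: the same change on two cores in this assay, a 1.4-fold higher number (0.14 log units; within the scatter) from compound 1 to compound 2 and a 1.2-fold higher number (0.09 log units; within the scatter) from compound 3 to compound 4, 1.1-fold (0.05 log units) apart, within the scatter of two such steps. So far as these two cores go, the change carries over without a detectable difference, even though the methyl enters a different kind of ring in each. This does not show that methyl raises the number on either core, since neither step leaves the scatter, and two such small steps cannot say how the change would behave on a further core or where it has a larger effect.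

The compounds shown leave open whether anything larger or of another kind on that ring carbon, such as an ethyl group, an amine or a carboxylic acid, would move the number beyond the scatter. They also leave open what a longer chain joining the two parts of the molecule would do in this assay.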